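A few compounds are considered here, and "the series" means these few. Any claim that something is new, unique, unknown or untested is made for them only; others in the source may bear on it.

The shared core, seen in compound 1 `O=C(Nc1ccc(-c2cnc3cc(C4=CCN(C5COC5)CC4)ccn23)cc1)c1ccc([N+](=O)[O-])o1`, carries a nitrofuran amide at one end and a variable group on an aromatic carbon at the other. In a functional assay on AGS cells (Homo sapiens) for antiproliferative activity, read by CCK-8 assay, with a stated time of 72 h (a higher number here means a weaker inhibitor, a lower number a stronger inhibitor), compound 1 gives 790 nM. Compound 2 `CC1(O)CCN(c2ccn3c(-c4ccc(NC(=O)c5ccc([N+](=O)[O-])o5)cc4)cnc3c2)CC1` gives 1530 nM in this assay, and compound 3 `O=C(Nc1ccc(-c2cnc3cc(N4CCCC4)ccn23)cc1)c1ccc([N+](=O)[O-])o1` gives 1240 nM. The three numbers sit close together: the step of a 1.6-fold higher number from compound 1 to compound 3 (0.20 log units; within the scatter) and the step of a 1.2-fold lower number from compound 2 to compound 3 (0.09 log units; within the scatter) are both within the usual scatter, as is a 1.9-fold higher number from compound 1 to compound 2 (0.29 log units; within the scatter), so no one of the three can be called stronger or weaker than the others.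

Compound 4 `O=C(Nc1ccc(-c2cnc3cc(Cl)ccn23)cc1)c1ccc([N+](=O)[O-])o1` differs from compound 3 in one place: chloro in place of pyrrolidin-1-yl on an aromatic carbon. All three measured steps change the group at this same aromatic carbon, and none of them moves the number beyond the scatter. The expected step of a 1.0-fold lower number from compound 3 to compound 4 (0.01 log units; within the scatter) is therefore also small, with no clear direction. Compound 4 is expected to give about 1200 nM in this assay, within a range from 500 nM to 3000 nM.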

Compound 4, half-maximal inhibitory concentration: 1700 nM
Beside the measured number, compound 4's estimate is 1.4-fold (0.15 log units) below it; the range from low to high includes it.
By their numbers in this assay, from the lowest: compounds 1, 3, 2 and 4 (each within the scatter of the next, the first and the last beyond it).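

In this assay, a single chlorine atom with no ring stands level with both ring amines, as a 1.4-fold higher number from compound 3 to compound 4 (0.14 log units; within the scatter) and a 1.1-fold higher number from compound 2 to compound 4 (0.05 log units; within the scatter) show. The one gap at this aromatic carbon that passes the usual scatter is a 2.2-fold higher number from compound 1 to compound 4 (0.33 log units; beyond the scatter), a modest step in which one chlorine atom replaces the whole two-ring group of compound 1. So this position accepts groups ranging from a single chlorine atom to the two-ring group of compound 1 with little spread in the numbers, and compound 4 only separates from compound 1, not from compound 2 or compound 3.

From the compounds shown here alone, whether a carboxylic acid, a primary amine or a longer alkyl chain at this carbon would give a larger step remains open. Nothing available explains why these numbers lie so close together.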